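Pyrrolidin-1-yl in place of oxan-4-yl in compound 3

The source may hold more compounds than are shown below. What is called first, only, known or untested is meant among the compounds shown, and "the series" means these compounds.

In a physicochemical assay for solubility (a lower number here means a less soluble compound, a higher number a more soluble compound), compound 3 (`C[C@H]1C(=O)N(C)C=Cc2cc(CC3CCOCC3)ccc21`) gives >= 111 ug/mL, which is a limit and not a number. Compound 1 (`COCCOc1ccc2c(c1)C=CN(C)C(=O)[C@@H]2C`) gives >= 128 ug/mL, also a limit. Compound 2 (`C[C@H]1C(=O)N(C)C=Cc2cc(OC(CO)CO)ccc21`) gives >= 142 ug/mL, again a limit. Compound 4 (`C[C@H]1C(=O)N(C)C=Cc2cc(CN3CCCC3)ccc21`) carries pyrrolidin-1-yl in place of oxan-4-yl on a saturated chain carbon bound to an aromatic carbon. The nearest measured changes are a step that the two limits leave unreadable from compound 1 to compound 3 and a step that the two limits leave unreadable from compound 2 to compound 3, and neither has a readable size. With no size to carry over, no step beyond the scatter is expected in this assay. The expected change is a step that the limit leaves unreadable from compound 3 to compound 4. For compound 4 the estimate is 120 ug/mL, with an expected range of 70 ug/mL to 160 ug/mL.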

Compound 4, solubility: >= 97 ug/mL
Compound 4 gave a limit, no number; the forecaster's own chance of this, stated with the estimate: 70%; the middle value lies beyond the limit too.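

For the compounds shown here, compound 4, like compound 1, compound 2 and compound 3, gives only a limit in this assay, so no step to compound 4 can be read. The compounds shown leave open whether pyrrolidin-1-yl in place of oxan-4-yl changes the read-out at all.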